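Lengthening the alkyl chain on the shared core, one carbon at a time

A few compounds are considered here, and "the series" means these few. Any claim that something is new, unique, unknown or untested is made for them only; others in the source may bear on it.

Measured in a functional assay on the whole organism with Rattus norvegicus as the target, read by paw edema, with a stated time of 5 h, at a dose of 5 mg/kg by the oral route; on this read-out lower numbers stand for a weaker effect and higher numbers for a stronger effect at the one dose given:
compound 1 `CCCCn1c(CCC)nc2cc(N)ccc21` gives 59.1%
compound 2 `CCCCCn1c(CCC)nc2cc(N)ccc21` gives 45.9%

Among the measured compounds shown here, compound 2 stands lowest of the two numbers, its only neighbour being compound 1. For the measured compounds named here, the one measured step, a number 13.2 percentage points lower from compound 1 to compound 2 (beyond the scatter), came with methyl in place of hydrogen on a saturated chain carbon, four bonds along the chain from an aromatic nitrogen. Compound 3 `CCCCCCn1c(CCC)nc2cc(N)ccc21` differs from compound 2 by methyl in place of hydrogen on a saturated chain carbon, five bonds along the chain from an aromatic nitrogen. With a single step to go on, a further modest fall in this assay is expected, since the earlier step of a number 13.2 percentage points lower from compound 1 to compound 2 (beyond the scatter) went down. Compound 3 is expected to give about 37%, within 20% to 54%. This expected change is a number 8.9 percentage points lower from compound 2 to compound 3 (within the scatter).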

Compound 3, a percentage reported as activity, at one dose (the size of the read-out at that dose, not a potency): 33.1%
Compound 3: the middle estimate sits 3.9 percentage points above what was measured, and the stated range covers the measured number.
By their numbers in this assay, from the lowest: compound 3; then compound 2; then compound 1.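

In this assay, the fall in effect continues when the chain grows further out, with methyl in place of hydrogen five bonds along it giving a number 12.8 percentage points lower from compound 2 to compound 3 (beyond the scatter). Across the whole series the result is a number 26 percentage points lower from compound 1 to compound 3 (beyond the scatter), so each added carbon has lowered the number, and no compound shown goes against this trend. Nothing here bears on the cause of this fall.

Still open, going by these compounds, is whether a longer chain, such as heptyl, would lower the number again. A chain ending in a hydroxyl or a carboxylic acid also remains untested among the compounds shown.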